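Nitro to bromo on the aryl group of the quinazoline series

The compounds below may be only part of what the source reports. "The series", "measured", "known", "first", "only" and "open" are said of these compounds alone.

Measured compounds:
compound 1 `FC(F)(F)c1ccc(CNc2nc(-c3ccccc3C(F)(F)F)nc3ccccc23)cc1`, 8900 nM
compound 2 `O=[N+]([O-])c1ccccc1-c1nc(NCc2ccc(-c3cccnc3)cc2)c2ccccc2n1`, 7800 nM

In an assay on a protein complex for inhibition of ubiquitin carboxyl-terminal hydrolase 1/WD repeat-containing protein 48 (Homo sapiens), read by fluorescence (a lower number here means a stronger inhibitor, a higher number a weaker inhibitor), compound 2 gives 7800 nM, the lowest of the two numbers at hand. The nearest is compound 1, whose reading of 8900 nM lies within the scatter of compound 2, so the two cannot be told apart. Compound 3 `Brc1ccccc1-c1nc(NCc2ccc(-c3cccnc3)cc2)c2ccccc2n1` is not yet measured in this assay. It differs from compound 2 in one place: bromo in place of nitro on an aromatic carbon, that is, 2-nitrophenyl becomes 2-bromophenyl. Going by the values given here, no step between measured compounds covers such a change, and the only comparison available, compound 1 against compound 2, shows that two different groups at this place give indistinguishable numbers. The expected step from compound 2 to compound 3 is therefore a 1.0-fold higher number from compound 2 to compound 3 (0.01 log units; within the scatter), none beyond the scatter. Compound 3 is estimated at 8000 nM in this assay, with a range from 3000 nM to 25000 nM.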

Compound 3, half-maximal inhibitory concentration: 1600 nM
Estimate against measurement, compound 3: 5.0-fold (0.70 log units) above, and the stated range ends above it.
By their numbers in this assay, from the lowest: compound 3; then compounds 2 and 1 (each within the scatter of the next).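

In this assay, the change from 2-nitrophenyl to 2-bromophenyl gives a 4.9-fold lower number from compound 2 to compound 3 (0.69 log units; beyond the scatter) and so shows that this place on the aryl group responds to the group it carries, which compound 1 and compound 2, differing in more than one place, could not show. The hydrogen-bond acceptors of the nitro group are not needed to reach this reading, since a single bromine atom without any acceptor stands in their place and the number still falls. No measurement of any property of these groups is at hand to account for the step.

Going by these compounds, whether the gain is particular to bromo or also holds for chloro, methoxy or an amine at this place remains open. Also open, on these data alone, is whether the same exchange gives a similar step on the other substituent carried by compound 1.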